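The compounds below may be only part of what the source reports. "The series", "measured", "known", "first", "only" and "open" are said of these compounds alone.

Measured compounds:

Compound 1, `CSc1nncc2c(C)nc(C)n12`: in a functional assay for inhibition, with Homo sapiens as the target (on this read-out higher numbers stand for weaker inhibition and lower numbers for stronger inhibition), compound 1 gives > 48000 nM, a limit of the assay.
Compound 2, `CCCc1nc(C)c2c(C)nnc(SC)n12`: in this assay compound 2 gives > 48000 nM, again only a limit.
Compound 3, `Cc1nnc(S)n2c(C)nc(C)c12`: in this assay compound 3 gives > 48000 nM, also a limit and not a number.

Compound 3 thus stands where every value shown stands, since the limit of > 48000 nM in this assay, at which 3 of the 3 values shown sit, describes all three results. No measured step separates any two of these compounds, so no size of change can be read from them.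

Compound 4, `CSc1nnc(C)c2c(C)nc(C)n12`, differs from compound 3 by methyl in place of hydrogen on a sulfur. For compound 4 the step that the limit leaves unreadable from compound 3 to compound 4 in this assay is expected to be none beyond the scatter, with compound 1 carrying the same methylsulfanyl and sitting at the limit > 48000 nM. Compound 4 is estimated at 70000 nM, within 20000 nM to 250000 nM, most likely reported again only as a limit.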

Compound 4, half-maximal inhibitory concentration: > 48000 nM
Compound 4: a limit, no number; the forecaster's own chance of this, stated with the estimate: 85%; the middle value is on the limit's open side.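

The steps from compound 1, compound 2 and compound 3 to compound 4 cannot be read in this assay, since all four results are limits, not numbers: the limit of > 48000 nM in this assay, at which 4 of the 4 values shown sit.

As far as these compounds go, whether any change on the shared core gives a measurable value in this assay stays open.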